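Notes on replacing naphthalen-2-yl in compound 3

A few compounds are considered here, and "the series" means these few. Any claim that something is new, unique, unknown or untested is made for them only; others in the source may bear on it.

Compound 1 `O=C1C=CC2(C=C1)OCC(=O)N2c1nc(-c2ccc3c(c2)OCCO3)nn1-c1ccccc1`: 70 nM
Compound 2 `O=C1C=CC2(C=C1)OCC(=O)N2c1nc(-c2ccc(F)c3ccccc23)nn1-c1ccccc1`: 200 nM
Compound 3 `O=C1C=CC2(C=C1)OCC(=O)N2c1nc(-c2ccc3ccccc3c2)nn1-c1ccccc1`: 120 nM

All three values come from a functional assay on HeLa cells (Homo sapiens) for antiproliferative activity, with a stated time of 5 days; a higher number here means a weaker inhibitor, a lower number a stronger inhibitor. Compound 3, at 120 nM, lies within the scatter of both other compounds, with the measured steps being a 1.7-fold higher number from compound 1 to compound 3 (0.23 log units; within the scatter) and a 1.7-fold lower number from compound 2 to compound 3 (0.22 log units; within the scatter). The step of a 2.9-fold higher number from compound 1 to compound 2 (0.46 log units; beyond the scatter) is the only one beyond the scatter, and it is modest.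

Compound 4 `O=C1C=CC2(C=C1)OCC(=O)N2c1nc(-c2cccc(Cl)c2)nn1-c1ccccc1` has not yet been measured. It carries 3-chlorophenyl in place of naphthalen-2-yl on an aromatic carbon of a five-membered aromatic ring with 3 nitrogen: 3-chlorophenyl in place of naphthalen-2-yl on an aromatic carbon.

All three measured steps exchange the group at this same carbon, so they are the relevant guide, and none is larger than modest. Among the compounds with values here, none of the measured compounds carries 3-chlorophenyl or any other group with one aromatic ring at this carbon, which leaves the direction open and the range wide. No step beyond the scatter is therefore expected in this assay. The expected step is a 1.1-fold higher number from compound 3 to compound 4 (0.03 log units; within the scatter). Compound 4 is estimated at 130 nM, with an expected range of 55 nM to 320 nM.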

Compound 4, half-maximal inhibitory concentration: 45.3 nM
The estimate for compound 4 lay 2.9-fold (0.46 log units) above the measured number, outside the stated range (below it).
By their numbers in this assay, from the lowest: compounds 4, 1, 3 and 2 (each within the scatter of the next, the first and the last beyond it).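

In this assay, a single aromatic ring at this carbon is enough to retain activity: 3-chlorophenyl gives a 2.6-fold lower number from compound 3 to compound 4 (0.42 log units; beyond the scatter) and a 4.4-fold lower number from compound 2 to compound 4 (0.64 log units; beyond the scatter), so neither naphthalen-2-yl nor 4-fluoronaphthalen-1-yl, each with two six-membered aromatic rings of carbon only, is needed here. The comparison with the remaining bicyclic group, 2,3-dihydro-1,4-benzodioxin-6-yl, gives a 1.5-fold lower number from compound 1 to compound 4 (0.19 log units; within the scatter), so these two compounds cannot be separated and compound 4 does not stand alone at the low end of the series, even though 3-chlorophenyl has fewer heavy atoms than naphthalen-2-yl. Nothing available accounts for this result.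

The compounds shown do not tell whether the chlorine contributes at all, since a plain phenyl group is absent from them, and they do not separate the effect of the chlorine from that of losing the second ring. As far as these compounds go, how this carbon responds to a phenyl ring bearing an amine or a carboxylic acid also remains open.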